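The compounds below may be only part of what the source reports. "The series", "measured", "known", "first", "only" and "open" are said of these compounds alone.

Values in a functional assay on PC-3 cells (Homo sapiens) for antiproliferative activity, read by MTT assay (on this read-out lower numbers stand for stronger inhibition and higher numbers for weaker inhibition), for the three measured members of the series:

- compound 1 `Cn1c(=O)c(=O)n(C2CCCC2)c2nc(N/N=C/c3ccc(Cl)cc3)ncc21`: 8420 nM
- compound 2 `Cn1c(=O)c(=O)n(C2CCCC2)c2nc(N/N=C/c3ccc(C(F)(F)F)cc3)ncc21`: 23600 nM
- compound 3 `Cn1c(=O)c(=O)n(C2CCCC2)c2nc(N/N=C/c3cccs3)ncc21`: 75600 nM

Compound 3 stands at the highest number of the three, that is, the weakest inhibition recorded; its nearest neighbour is compound 2 and the furthest is compound 1, both separated from it by more than the usual scatter.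

The next compound, compound 4 `Cn1c(=O)c(=O)n(C2CCCC2)c2nc(N/N=C/c3cccc(O)c3)ncc21`, differs from compound 3 in one place: 3-hydroxyphenyl in place of thiophen-2-yl on a carbon with a double bond to nitrogen. Within the data shown here, no measured step involves a hydroxyl group on any ring, so the only steps that bear on this change are the two in which a six-membered carbon ring gives way to thiophen-2-yl on the same carbon, namely a 9.0-fold higher number from compound 1 to compound 3 (0.95 log units; beyond the scatter) and a 3.2-fold higher number from compound 2 to compound 3 (0.51 log units; beyond the scatter). Read in reverse, both point to a lower number when a phenyl ring returns in place of the thiophen-2-yl group, with the size depending on what the ring carries, and the two measured phenyl substituents themselves differ by a 2.8-fold higher number from compound 1 to compound 2 (0.45 log units; beyond the scatter).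

On that basis compound 4 is expected to give a lower number than compound 3 in this assay, a step of roughly a 3.8-fold lower number from compound 3 to compound 4 (0.58 log units; beyond the scatter). The estimate for compound 4 is 20000 nM, expected to fall between 6000 nM and 70000 nM.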

Compound 4, half-maximal inhibitory concentration: 36300 nM
Beside the measured number, compound 4's estimate is 1.8-fold (0.26 log units) below it; the range from low to high includes it.
By their numbers in this assay, from the lowest: compound 1; then compounds 2 and 4 (each within the scatter of the next); then compound 3.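

In this assay, a six-membered carbon ring again gives a lower number than thiophen-2-yl at this position, now with a ring that carries a hydrogen-bond donor, with a 2.1-fold lower number from compound 3 to compound 4 (0.32 log units; beyond the scatter). 3-Hydroxyphenyl cannot be separated from 4-(trifluoromethyl)phenyl, with a 1.5-fold higher number from compound 2 to compound 4 (0.19 log units; within the scatter), but it does not match 4-chlorophenyl, with a 4.3-fold higher number from compound 1 to compound 4 (0.63 log units; beyond the scatter), so compound 1 keeps the lowest number of the four, its steps to all three others lying beyond the scatter. No measurement shown accounts for any of these steps, and the hydroxyl group's contribution cannot be assigned from them.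

3-Hydroxyphenyl and 4-chlorophenyl differ in both the substituent and its place on the ring, so the compounds shown do not separate those two changes. Also open, from the compounds shown here alone, is how unsubstituted phenyl, or a phenyl ring carrying a methoxy group, an amine or a carboxylic acid, would compare on the carbon with a double bond to nitrogen, and whether any of them would give a number lower than that of compound 1.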